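Changing the Amide Side Chain of Compound 1

This account rests on a few compounds, and the source may have more. Where it says the series, first, only, none or still open, it means among the compounds named here.

In a functional assay on HepG2 cells (Homo sapiens), read by MTT assay, with a stated time of 48 h (on this read-out higher numbers stand for weaker inhibition and lower numbers for stronger inhibition), compound 1 `CCn1c(C(=O)NCCN(C)C)ccc1C(CC)(CC)c1ccc(OCC(=O)C(C)(C)C)c(C)c1` gives 2300 nM, the higher of the two exact numbers, and compound 2 `CCn1c(C(=O)NCCN(C)C)ccc1C(CC)(CC)c1ccc(OCC(O)C(C)(C)C)c(C)c1` gives 870 nM. Compound 3 `C#CCNC(=O)c1ccc(C(CC)(CC)c2ccc(OCC(O)C(C)(C)C)c(C)c2)n1CC` gives > 50000 nM, which is a limit of the assay. Compound 4 `CCn1c(C(=O)N(C)CC(=O)O)ccc1C(CC)(CC)c1ccc(OCC(=O)C(C)(C)C)c(C)c1` differs from compound 1 in one place: (carboxymethyl)(methyl)amino in place of (2-(dimethylamino)ethyl)amino on a carbonyl carbon. The modest step of a 2.6-fold lower number from compound 1 to compound 2 (0.42 log units; beyond the scatter) changes (tert-butyl)carbonyl, a group that compound 4 keeps, so it bears little here. More relevant is the large step of an at least 57-fold higher number from compound 2 to compound 3 (1.75 log units; beyond the scatter), where ethynyl stands in place of (dimethylamino)methyl, since compound 4 also loses that dimethylamino end. A large move toward weaker inhibition is therefore expected, estimated as a 13-fold higher number from compound 1 to compound 4 (1.12 log units; beyond the scatter). For compound 4 the estimate is 30000 nM, with an expected range of 7000 nM to 100000 nM.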

Compound 4, half-maximal inhibitory concentration: 25200 nM
The estimate for compound 4 lay 1.2-fold (0.08 log units) above the measured number; measured number inside the range.
By their numbers in this assay, from the lowest: compound 2; then compound 1; then compound 4. At a limit, above all of these: compound 3.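

Compound 4 keeps the (tert-butyl)carbonyl group of compound 1 and changes only the side chain on the carbonyl carbon, and this gives an 11-fold higher number from compound 1 to compound 4 (1.04 log units; beyond the scatter). The side chain therefore matters with this group in place too, and here the loss has an exact size, although both side chains count 6 heavy atoms. Nothing measured here accounts for the loss.

This change removes the dimethylamino end, adds a carboxylic acid and replaces the amide hydrogen with a methyl group, so these effects cannot be separated. As far as these compounds go, it remains open how (carboxymethyl)amino or a longer chain ending in dimethylamino would read.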